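Aryl swap in compound 4: expected single-point activity

A few compounds are considered here, and "the series" means these few. Any claim that something is new, unique, unknown or untested is made for them only; others in the source may bear on it.

Compound 3 `Cc1nc(-c2cccc(F)c2)sc1COc1ccc2c(c1)OCC2CC(=O)O` gives 56.9% in a functional assay on CHO cells for agonist activity at Free fatty acid receptor 1 (Homo sapiens), read by FLIPR and calcium flux, tested at 100 nM (a higher number here means a stronger effect of the compound at the concentration tested, a lower number a weaker effect), and holds the highest of the three numbers, though compound 2 `Cc1ccc(-c2nc(C)c(COc3ccc4c(c3)OCC4CC(=O)O)s2)cc1` lies within the scatter of it with 54.9%; only compound 1 `Cc1nc(-c2cccc3ccccc23)sc1COc1ccc2c(c1)OCC2CC(=O)O`, at 8.53%, stands clearly apart. Compound 4 `Cc1nc(-c2ccccc2C(F)(F)F)sc1COc1ccc2c(c1)OCC2CC(=O)O` has not been measured; the change is 2-(trifluoromethyl)phenyl in place of 3-fluorophenyl on an aromatic carbon. Among the measured compounds shown here, no measured step covers this pair. For the measured compounds named here, the steps that bear on the aryl group are a number 48.4 percentage points higher from compound 1 to compound 3 (beyond the scatter) and a number 46.4 percentage points higher from compound 1 to compound 2 (beyond the scatter), both large, whereas a number 2 percentage points higher from compound 2 to compound 3 (within the scatter) stayed within the scatter, so two different phenyl groups gave like numbers. With one phenyl group replacing another, a step no larger than the scatter is expected for compound 4, a number 8.9 percentage points lower from compound 3 to compound 4 (within the scatter). Compound 4 is therefore estimated at 48%, with a range from 22% to 68%.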

Compound 4, a percentage reported as activity, at one concentration (the size of the read-out at that concentration, not a potency): 7.76%
For compound 4 the middle estimate is 40.2 percentage points above the measured one, and the stated range ends above it.
By their numbers in this assay, from the lowest: compounds 4 and 1 (each within the scatter of the next); then compounds 2 and 3 (each within the scatter of the next).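

The aryl position on the five-membered aromatic ring with 1 nitrogen and 1 sulfur does not accept every phenyl group alike: 2-(trifluoromethyl)phenyl gives a number 49.1 percentage points lower from compound 3 to compound 4 (beyond the scatter) and a number 47.1 percentage points lower from compound 2 to compound 4 (beyond the scatter), so the match between 3-fluorophenyl and 4-methylphenyl does not extend to it. With a number 0.8 percentage points lower from compound 1 to compound 4 (within the scatter), a substituted phenyl group now sits level with naphthalen-1-yl, so low numbers are not confined to the naphthalen-1-yl compound. Nothing at hand accounts for the loss.

Still open, on these data alone, is whether the loss follows the trifluoromethyl group itself or its place on the phenyl ring. As far as these compounds go, how a plain phenyl or a pyridyl group would read at this position is also open.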